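Swapping one group on compound 2: what to expect

The compounds below may be only part of what the source reports. "The series", "measured", "known", "first", "only" and "open" are said of these compounds alone.

- Compound 1 `CCCCc1nc(Cl)c(COC)n1Cc1ccc(-c2ccccc2-c2nn[nH]n2)cc1` gives 6
- Compound 2 `CCCCc1nc(Cl)c(CO)n1Cc1ccc(-c2ccccc2-c2[nH]nnc2C(=O)OC)cc1` gives 7
- Compound 3 `CCCCc1nc(Cl)c(COC)n1Cc1ccc(-c2ccccc2NS(=O)(=O)C(F)(F)F)cc1` gives 4.5

In a physicochemical assay (Rattus norvegicus), compound 2 stands highest of the three with 7, and the gaps down to compound 1 and compound 3 are both beyond the usual scatter.

Compound 4 `CCCCc1nc(Cl)c(CO)n1Cc1ccc(-c2ccccc2C(=O)NO)cc1` changes one group of compound 2: hydroxycarbamoyl in place of 4-(methoxycarbonyl)-1H-1,2,3-triazol-5-yl on an aromatic carbon. In words, hydroxycarbamoyl takes the place of 4-(methoxycarbonyl)-1H-1,2,3-triazol-5-yl on an aromatic carbon, ortho to a large group.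

For the measured compounds named here, only one measured step involves a swap of this kind, also on an aromatic carbon. It is a number 1.50 log units lower from compound 1 to compound 3 (beyond the scatter), a large step in which ((trifluoromethyl)sulfonyl)amino replaces 2H-tetrazol-5-yl. That step shows that one such exchange can move the number well beyond the scatter. Going by the values given here, it shares neither group with the present change, however, and no measured compound carries hydroxycarbamoyl, so it guides the size of the step but not its direction.

The direction is therefore a judgement, and a rise of similar size is expected. The expected change is a number 1.50 log units higher from compound 2 to compound 4 (beyond the scatter). For compound 4 the estimated value in this assay is 8.5, with an expected range from 7.6 to 9.4.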

Compound 4, acid dissociation constant: 10.5
For compound 4 the middle estimate is 2.00 log units below the measured one; measured number outside the range, above it.
By their numbers in this assay, from the lowest: compound 3; then compound 1; then compound 2; then compound 4.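

In this assay, for the compounds shown here, a number 3.50 log units higher from compound 2 to compound 4 (beyond the scatter) when hydroxycarbamoyl replaces 4-(methoxycarbonyl)-1H-1,2,3-triazol-5-yl on this aromatic carbon, which gives the first measured value for hydroxycarbamoyl in this set. Going by these compounds alone, the only earlier exchange at this kind of place was downward, a number 1.50 log units lower from compound 1 to compound 3 (beyond the scatter), so the two steps together show that a single group swap here can move the number clearly in either direction, and that this new swap moves it further than the earlier one. Nothing in the data shown explains why the number moves so far.

This single pair also cannot separate the effect of bringing in hydroxycarbamoyl from that of removing the five-membered ring, since both happen in the same swap, and the two groups differ in size and in their counts of hydrogen-bond donors and acceptors as well. As far as these compounds go, how a carboxylic acid or a simple primary amide on this aromatic carbon would compare remains open, as does whether hydroxycarbamoyl would give a step of similar size on the core of compound 1.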